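The compounds below may be only part of what the source reports. "The series", "measured", "known", "first", "only" and "open" are said of these compounds alone.

Compound 1 `CC(C)(C)NCC(=O)Nc1nc2ccc(Cl)cc2s1`: 3.02. Compound 2 `Oc1ccc(/C=N/NC(=S)Nc2nc3ccc(Cl)cc3s2)cc1`: 4.78. Compound 3 `O=C(CNc1ccc(Cl)cc1)Nc1nc2ccc(Cl)cc2s1`: 4.24.

In a physicochemical assay for lipophilicity, in phosphate buffer, measured as octanol-water partition (a lower number here means a more polar compound, a higher number a more lipophilic compound), compound 2 gives the highest of these three numbers, lying beyond the scatter above compound 3 and furthest from compound 1. Compound 4 `CN(C)c1ccc(/C=N/NC(=S)Nc2nc3ccc(Cl)cc3s2)cc1` differs from compound 2 in one place: dimethylamino in place of hydroxy on an aromatic carbon. Going by the values given here, the only measured step, a number 1.22 log units higher from compound 1 to compound 3 (beyond the scatter), concerns a different exchange on an amine nitrogen and bears on the present change only loosely; no measured pair shows dimethylamino in place of hydroxy. A modest rise is nonetheless expected, the step from compound 2 being estimated at a number 0.62 log units higher from compound 2 to compound 4 (beyond the scatter). For compound 4 the expected value in this assay is 5.4, within a range from 4.9 to 5.9.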

Compound 4, partition coefficient: 5.24
Estimate against measurement, compound 4: 0.16 log units above; measured number inside the range.
By their numbers in this assay, from the lowest: compound 1; then compound 3; then compound 2; then compound 4.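

Going by these compounds alone, on the aromatic carbon para to a large group, dimethylamino in place of hydroxy gives a number 0.46 log units higher from compound 2 to compound 4 (beyond the scatter) in this assay, the first measured step at this position. The entering group has no hydrogen-bond donor and more heavy atoms than hydroxy, so these two differences arrive together and this single pair cannot separate them.

From the compounds shown here alone, whether methoxy or a plain amine in this place would fall nearer compound 2 or compound 4 remains open, and such a comparison could help pull the two differences apart. The cause of the step also remains open, as no measurement shown here accounts for it.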